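Removal of one nitrooxy group from the pivalate chain

The source may report more compounds than this note shows. Statements on the series, on what has been measured and on what is new or still open speak of the compounds shown alone.

Compound 1 `Cc1cc(OC(=O)C(C)(C)CCC(CO[N+](=O)[O-])O[N+](=O)[O-])n(-c2ccccc2)n1` is the reference point of this pair. Among the measured compounds shown here, in an ADME assay on liver (Rattus norvegicus, strain Wistar) for metabolic stability, read by HPLC, tested at 200 uM (a lower number here means that the compound disappears faster, a higher number that the compound lasts longer), compound 1 gives 0.05 h, the only plain number available so far. Compound 2 `Cc1cc(OC(=O)OCCCCC(CO[N+](=O)[O-])O[N+](=O)[O-])n(-c2ccccc2)n1` sits at a limit of the assay rather than at a number, < 0.0167 h. For the measured compounds named here, that limit is the only other piece of evidence: the limit of < 0.0167 h in this assay, at which 1 of the 2 values shown sits. Compound 1 therefore stands above the limit, and nothing else places it.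

Compound 3 `Cc1cc(OC(=O)C(C)(C)CCCCO[N+](=O)[O-])n(-c2ccccc2)n1` differs from compound 1 in one place: hydrogen in place of nitrooxy on a saturated chain carbon bound to two saturated chain carbons. The ester link to the shared core and the rest of the chain are unchanged.

Going by the values given here, with no measured step between two numbered compounds to lean on, the expectation for this change is a step of no size beyond the usual scatter, in no set direction. Compound 3 is thus expected to give 0.06 h in this assay, with a range from 0.02 h to 0.2 h. The expected step of a 1.2-fold higher number from compound 1 to compound 3 (0.08 log units; within the scatter) would stay within the scatter of repeated measurement, pending the result.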

Compound 3, half-life in the liver assay: 0.0333 h
Compound 3: the middle estimate sits 1.8-fold (0.26 log units) above what was measured, and the stated range covers the measured number.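

Among the compounds shown here, in the liver assay, hydrogen in place of nitrooxy on a saturated chain carbon bound to two saturated chain carbons gives a 1.5-fold lower number from compound 1 to compound 3 (0.18 log units; within the scatter), the first step that can be read, and at this position the change from 1,2-bis(nitrooxy)ethyl to 2-(nitrooxy)ethyl leaves no difference that repeated measurement could separate. In a physicochemical assay for metabolic stability, read by HPLC (a lower number here means that the compound disappears faster, a higher number that the compound lasts longer), compound 1 gives 16 h and compound 3 gives 22 h. In the physicochemical assay the same change reads a 1.4-fold higher number from compound 1 to compound 3 (0.14 log units; within the scatter), so neither assay separates the two compounds, and the second nitrooxy group on this chain shows no measurable effect on half-life in either one.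

The value of compound 2 is a limit of the assay and not a number, so no step to it can be read: the limit of < 0.0167 h in the liver assay, at which 1 of the 3 values shown sits.
Whether an amine, a carboxylic acid or a longer chain at this place would move the half-life beyond the scatter stays open, and a single step in each assay names no cause for either result.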